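The source may hold more compounds than are shown below. What is called first, only, known or untested is meant among the compounds shown, and "the series" means these compounds.

Compound 3 `Clc1ccc(Cc2nn3cc(-c4ccccc4)nc3s2)cc1` stands at a limit in a functional assay on HeLa cells (Homo sapiens) for cytotoxicity, with a stated time of 72 h; on this read-out higher numbers stand for weaker inhibition and lower numbers for stronger inhibition: in this assay compound 3 gives > 250000 nM, a limit of the assay and not a number. Compound 2 `Cc1ccc(-c2cn3nc(Cc4ccc(Cl)cc4)sc3n2)cc1` likewise gives only a limit in this assay, > 250000 nM. For the measured compounds named here, the single recorded step between these two, a step that the two limits leave unreadable from compound 2 to compound 3, is accordingly unreadable in size and direction. Compound 1 `Clc1ccc(-c2cn3nc(Cl)sc3n2)cc1`, a related member with a different substituent on the shared core, gives a number in this assay, 95000 nM.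

Compound 4 `Clc1ccc(Cc2nn3c(Br)c(-c4ccccc4)nc3s2)cc1` differs from compound 3 by bromo in place of hydrogen on an aromatic carbon. Going by the values given here, no measured step involves a bromo, and the one recorded step yields no usable size because the limit of > 250000 nM in this assay, at which 2 of the 3 values shown sit, covers two of the three values shown. Nothing in the data therefore points to a direction. The expected step is an at least 1.2-fold lower number from compound 3 to compound 4 (0.09 log units; that floor lies within the scatter), a change not beyond the scatter. Compound 4 is estimated to give about 200000 nM in this assay, with a range from 60000 nM to 600000 nM, and a fair chance that only a limit is reported again.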

Compound 4, half-maximal inhibitory concentration: > 250000 nM
Compound 4: only a limit was reported; the forecaster's own chance of this, stated with the estimate: 55%; at least 1.2-fold (0.09 log units) between middle value and limit.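

No new step can be read between compound 3 and compound 4, because both give only a limit of the assay and not a number: the limit of > 250000 nM in this assay, at which 3 of the 4 values shown sit.

The compounds shown leave open whether bromo in place of hydrogen on an aromatic carbon shifts the read-out in either direction.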